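Swapping phenyl for thiophen-2-yl on two related cores

The source may report more compounds than this note shows. Statements on the series, on what has been measured and on what is new or still open speak of the compounds shown alone.

Compound 1, `Oc1cccc(-c2cc(-c3ccccc3)cc(-c3ccccc3)n2)c1`, gives 19300 nM in a functional assay on MDA-MB-231 cells (Homo sapiens) for cytotoxicity, read by ELISA, with a stated time of 2 days; on this read-out higher numbers stand for weaker inhibition and lower numbers for stronger inhibition.
Compound 2, `Oc1cccc(-c2cc(-c3ccccc3)cc(-c3cccs3)n2)c1`, gives 18100 nM in this assay.
Compound 3, `Oc1cccc(-c2cc(-c3ccccc3)nc(-c3ccccc3)c2)c1`, gives 19500 nM in this assay.

Compound 1 and compound 2 share a core and differ in one group: thiophen-2-yl in place of phenyl on an aromatic carbon. The step this change made is a 1.1-fold lower number from compound 1 to compound 2 (0.03 log units; within the scatter), so the two values lie within the scatter of one another and neither can be called stronger or weaker.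

Compound 3 is built from the same atoms as compound 1, joined differently; the difference between the two cores is not broken down here. Compound 3 and compound 1 give values within the scatter of each other, as do compound 3 and compound 2.

Compound 4, `Oc1cccc(-c2cc(-c3ccccc3)nc(-c3cccs3)c2)c1`, has not yet been measured. It differs from compound 3 by the same change as that from compound 1 to compound 2: thiophen-2-yl in place of phenyl on an aromatic carbon. Because the earlier step of a 1.1-fold lower number from compound 1 to compound 2 (0.03 log units; within the scatter) stayed within the scatter, the step from compound 3 to compound 4 in this assay is expected to be small as well, about a 1.1-fold lower number from compound 3 to compound 4 (0.03 log units; within the scatter). Compound 4 is estimated at 18300 nM, expected to lie between 11000 nM and 30000 nM.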

Compound 4, half-maximal inhibitory concentration: 17700 nM
The estimate for compound 4 lay 1.0-fold (0.01 log units) above the measured number; low and high end bracket the measured number.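

The same swap of phenyl for thiophen-2-yl, now on the second core, gives a 1.1-fold lower number from compound 3 to compound 4 (0.04 log units; within the scatter) in this assay, so this step also cannot be called a gain or a loss. Set side by side, the two steps match, and on these two cores the swap carries over with the same outcome: the same change on two cores in this assay, a 1.1-fold lower number (0.03 log units; within the scatter) from compound 1 to compound 2 and a 1.1-fold lower number (0.04 log units; within the scatter) from compound 3 to compound 4, 1.0-fold (0.01 log units) apart, within the scatter of two such steps

This agreement is only between two steps too small to read, so it shows that the swap made no measurable difference on either core; it does not show that a change with a clear effect would carry over in the same way, and two cores are too few to support a rule for the series.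

All the compounds shown hold only phenyl or thiophen-2-yl at this place, and all keep the 3-hydroxyphenyl group. As far as these compounds go, what an amine, a carboxylic acid or a longer chain would do at this place remains open, as does the part played by the hydroxyl group.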